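Capping a Phenol on a Weak Growth Inhibitor

The source may report more compounds than this note shows. Statements on the series, on what has been measured and on what is new or still open speak of the compounds shown alone.

Three compounds carry a record in a functional assay on HL-60 cells (Homo sapiens) for inhibition, with a stated time of 72 h (on this read-out lower numbers stand for stronger inhibition of growth and higher numbers for weaker inhibition of growth), and a fourth awaits its measurement. Compound 1, `CCc1c(C(=O)NCc2c(O)ccc3cccc(O)c23)[nH]c(C)c1C(C)=O`, gives 1300 nM in this assay. Compound 3, `CNC(=O)c1[nH]c(C)c2c1CCCCC2=O`, carries no result in this assay; its entry reads "not determined" (no result reported). Compound 2, `CCN(CC)S(=O)(=O)c1ccc(O)c(NC(=O)c2[nH]c(C)c3c2CCCCC3=O)c1`, does not yield a number in this assay but only a limit, recorded as > 40000 nM. This is the ceiling of the measurement described by the limit of > 40000 nM in this assay, at which 1 of the 3 values shown sits, so compound 2 sits at the weak end of everything shown here, and no steps between measured compounds can be drawn from the three entries.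

Compound 4, `CCN(CC)S(=O)(=O)c1ccc(OC)c(NC(=O)c2[nH]c(C)c3c2CCCCC3=O)c1`, differs from compound 2 in one place: methyl in place of hydrogen on an oxygen on an aromatic ring. Nothing in the data ties this change to a measured effect, and the starting point is itself only a limit, so no step beyond the usual scatter is expected in this assay. The expected step of a number no higher from compound 2 to compound 4 (the limit leaves the size open) is therefore none, and compound 4 is most likely to come back as another limit. Compound 4 is estimated at 40000 nM, within a range from 10000 nM to 120000 nM.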

Compound 4, concentration for 50% growth inhibition: 1360 nM
For compound 4 the middle estimate is 29-fold (1.47 log units) above the measured one; the measured number lies below the stated range.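

In this assay, the change from hydroxy to methoxy on this aromatic ring turns a compound that gave only a limit into one with a measurable value, a move of an at least 29-fold lower number from compound 2 to compound 4 (1.46 log units; beyond the scatter). The earlier compounds shown here offered no comparison at all, so they could not show that this oxygen matters; this pair shows that replacing one hydrogen with a methyl, which adds just 1 carbon, is enough to produce a step beyond the scatter. The full size of that step stays unknown because the entry for compound 2 is a limit and not a number: the limit of > 40000 nM in this assay, at which 1 of the 4 values shown sits.

The compounds shown leave open whether methyl is special or whether other groups on this oxygen would serve as well, for example an ethyl, a longer chain ending in an amine, or one ending in a carboxylic acid. They also leave open whether the same change would have a similar effect on a different core, such as that of compound 1, which carries hydroxy groups of its own.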